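Swapping the Sulfonyl Aryl Group: Expected Clearance

A few compounds are considered here, and "the series" means these few. Any claim that something is new, unique, unknown or untested is made for them only; others in the source may bear on it.

Measured so far:
compound 1 `CCn1c([C@@H](C)NS(=O)(=O)c2ccc(Cl)cc2)nc2ccc(CN(C)C)cc21`: 30 mL.min-1.g-1
compound 2 `CCn1c([C@@H](C)NS(=O)(=O)c2ccc(C#N)cc2)nc2ccc(C(F)(F)F)cc21`: 34 mL.min-1.g-1

In an ADME assay (liver) for metabolic stability, with Liver microsome (Homo sapiens) as the target, read by LC-MS, using microsomes and NADPH, with a stated time of 5 min, at 37 degrees C (on this read-out higher numbers stand for fast clearance and lower numbers for slow clearance), compound 2 gives 34 mL.min-1.g-1, the higher of the two numbers, yet compound 1 at 30 mL.min-1.g-1 lies within the scatter, so the two are not distinguished. Compound 3 `CCCn1ncc(S(=O)(=O)N[C@H](C)c2nc3ccc(C(F)(F)F)cc3n2CC)c1C` is not yet measured. Its difference from compound 2 is 5-methyl-1-propyl-1H-pyrazol-4-yl in place of 4-cyanophenyl on a sulfonyl sulfur. For the measured compounds named here, no measured pair shows this kind of change, so the direction is unknown; a step no larger than the scatter, perhaps a mild rise, is expected, giving a 1.3-fold higher number from compound 2 to compound 3 (0.12 log units; within the scatter). Compound 3 is therefore estimated at 45 mL.min-1.g-1, with a range from 20 mL.min-1.g-1 to 110 mL.min-1.g-1.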

Compound 3, intrinsic clearance in microsomes: > 100 mL.min-1.g-1
Compound 3: no number, only a limit (the forecaster's own chance of this, stated with the estimate: 5%); at least 2.2-fold (0.34 log units) between middle value and limit.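

This is the first change shown with only the group on the sulfonyl sulfur differing, and it shows that this group can strongly affect clearance in this assay. Putting 5-methyl-1-propyl-1H-pyrazol-4-yl in place of 4-cyanophenyl gives an at least 2.9-fold higher number from compound 2 to compound 3 (0.46 log units; beyond the scatter). The value for compound 3 is a limit and not a number, so the full size of the step remains unknown: the limit of > 100 mL.min-1.g-1 in this assay, at which 1 of the 3 values shown sits.

From the compounds shown here alone, it remains open whether the propyl chain, the methyl group or the ring itself goes with this rise. An ethyl chain in place of propyl, or a carboxylic acid on the ring, could help separate these parts.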